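Working notes: from compound 1 toward compound 4

The source may report more compounds than this note shows. Statements on the series, on what has been measured and on what is new or still open speak of the compounds shown alone.

Compound 1 `Cc1ccc(/C=C/C[C@H]2C[C@@H]([C@@H](O)c3ccccc3)CO[C@@H]2c2ccccc2)cc1C`, compound 2 `COc1ccc(/C=C/C[C@@H]2C[C@@H]([C@@H](O)c3ccc(OC)c(OC)c3)CO[C@H]2c2ccccc2)cc1OC` and compound 3 `COc1ccc([C@H]2OC[C@H]([C@@H](O)c3ccc(OC)c(OC)c3)C[C@@H]2C/C=C/c2ccccc2)cc1OC` share one core. In a functional assay on HeLa cells (Homo sapiens) for cytotoxicity, read by WST assay, with a stated time of 48 h (a lower number here means a stronger inhibitor, a higher number a weaker inhibitor), compound 1 gives 10000 nM, compound 2 gives 16100 nM and compound 3 gives 14800 nM. Compound 1 shows the lowest of the three numbers, yet its gaps to compound 3 and to compound 2 both fall within the usual scatter, so no order among the three is claimed. Compound 4 `O=[N+]([O-])c1ccccc1/C=C/C[C@H]1C[C@@H]([C@@H](O)c2ccccc2)CO[C@@H]1c1ccccc1` is not yet measured. It differs from compound 1 in one place: 2-nitrophenyl in place of 3,4-dimethylphenyl on a double-bonded chain carbon bound to a double-bonded chain carbon. For the measured compounds named here, no step between measured compounds bears on this change, and the three measured values carry no trend to extend. The step is expected to stay within the scatter, no change at the digits printed from compound 1 to compound 4 (within the scatter). In this assay compound 4 is estimated at 10000 nM, between 4000 nM and 25000 nM.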

Compound 4, half-maximal inhibitory concentration: 11800 nM
For compound 4 the middle estimate is 1.2-fold (0.07 log units) below the measured one; the measured number falls inside the stated range.
By their numbers in this assay, from the lowest: compounds 1, 4, 3 and 2 (each within the scatter of the next).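

In this assay, 2-nitrophenyl in place of 3,4-dimethylphenyl on a double-bonded chain carbon bound to a double-bonded chain carbon gives a 1.2-fold higher number from compound 1 to compound 4 (0.07 log units; within the scatter), which lies within the scatter. For the compounds shown here, this is the only one-place step so far, and at this position the read-out does not tell the two aryl groups apart. Nothing available explains this result.

As far as these compounds go, whether an amine or a carboxylic acid on this aromatic ring would give a step beyond the scatter remains open. The same holds for a longer chain carrying the ring.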